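Removing One Methoxy Group from Compound 2

The source may report more compounds than this note shows. Statements on the series, on what has been measured and on what is new or still open speak of the compounds shown alone.

Three compounds share a common core in a functional assay on HT-29 cells (Homo sapiens) for inhibition, read by sulforhodamine B assay, with a stated time of 48 h; a lower number here means a stronger inhibitor of growth, a higher number a weaker inhibitor of growth. Compound 2 `COc1cc(-c2cc(/C=C/C(=O)c3ccc(N)cc3)[nH]n2)cc(OC)c1OC` gives 4820 nM, compound 3 `COc1ccc(C(=O)/C=C/c2cc(-c3cc(OC)c(OC)c(OC)c3)n[nH]2)cc1` gives 4190 nM, and compound 1 `COc1ccc(-c2cc(/C=C/C(=O)c3ccc(N)cc3)[nH]n2)cc1` gives 8110 nM. Compound 2 thus stands second highest of the three numbers, with its nearest neighbour compound 3 and its furthest neighbour compound 1; both gaps are within the usual scatter of this assay.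

Compound 4 `COc1ccc(-c2cc(/C=C/C(=O)c3ccc(N)cc3)[nH]n2)cc1OC` differs from compound 2 in one place: hydrogen in place of methoxy on an aromatic carbon. Within the data shown here, no measured step removes a methoxy group in this way. Among the measured compounds shown here, the only single step, a 1.2-fold lower number from compound 2 to compound 3 (0.06 log units; within the scatter), concerns the amino group and not the methoxy pattern, so it bears on the present change only by showing how little this core has moved so far. Compounds 1 and 2, which differ by two methoxy groups, give numbers within the scatter of each other, and compound 4 sits between them in structure.

On this basis no step beyond the scatter is expected in this assay; compound 4 is estimated at 6000 nM, with a range from 3000 nM to 13000 nM, which means an expected step of a 1.2-fold higher number from compound 2 to compound 4 (0.10 log units; within the scatter).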

Compound 4, concentration for total growth inhibition: 6910 nM
Compound 4: middle estimate off by 1.2-fold (0.06 log units), on the low side, and the stated range covers the measured number.
By their numbers in this assay, from the lowest: compounds 3, 2, 4 and 1 (each within the scatter of the next).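

In this assay, the methoxy group that stands ortho to a methoxy group and meta to a large group can be exchanged for hydrogen with a 1.4-fold higher number from compound 2 to compound 4 (0.16 log units; within the scatter), a step that stays within the scatter. Seen from the other side, adding a methoxy group gives a 1.2-fold lower number from compound 1 to compound 4 (0.07 log units; within the scatter), also within the scatter. Earlier, compounds 1 and 2 could only be compared across two methoxy groups at once, whereas compound 4 divides that difference into two single changes, and neither of them separates from the scatter in this assay; no accompanying measurement offers an account of these two steps.

The compounds shown carry only hydrogen or methoxy at this position, so what a hydroxyl group, a chlorine atom or a longer chain such as ethoxy would give there remains open. Also open, as far as these compounds go, is whether hydrogen in place of methoxy would read the same way on compound 3, which carries methoxy in place of amino on an aromatic carbon.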